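Aryl group exchange on the shared core and cytotoxicity

This account rests on a few compounds, and the source may have more. Where it says the series, first, only, none or still open, it means among the compounds named here.

Measured in an ADME assay on Huh7.5.1 cells (Homo sapiens) for cytotoxicity, read by ATP content, with a stated time of 48 h; on this read-out lower numbers stand for higher toxicity in this test and higher numbers for lower toxicity in this test:
- compound 1 `Cc1ccc(C)c(-c2nc(CN3CCC(C(=O)NCCCN4C[C@H](C)C[C@H](C)C4)CC3)c(C)o2)c1`: 4070 nM
- compound 2 `Cc1ccccc1-c1nc(CN2CCC(C(=O)NCCCN3CCC(C)CC3)CC2)c(C)o1`: 12300 nM
- compound 3 `CC[C@@H]1C[C@H](CC)CN(CCCNC(=O)C2CCN(Cc3nc(-c4c(F)cccc4F)oc3C)CC2)C1`: 12600 nM

Compound 1 gives the lowest number of the three, and both compound 2 and compound 3 stand higher, each beyond the scatter, so compound 1 is the most toxic of the measured set in this assay.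

Compound 4 `COc1cccc(Br)c1-c1nc(CN2CCC(C(=O)NCCCN3C[C@H](C)C[C@H](C)C3)CC2)c(C)o1` is the next compound. Its difference from compound 1: 2-bromo-6-methoxyphenyl in place of 2,5-dimethylphenyl on an aromatic carbon. Going by the values given here, no measured pair shows a change of this kind, so the expectation rests on the spread of the three numbers alone. A modest step toward a higher number, at or just beyond the scatter, is expected, a 1.6-fold higher number from compound 1 to compound 4 (0.20 log units; within the scatter). For compound 4 the estimate is 6500 nM, with a range from 2500 nM to 16000 nM.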

Compound 4, half-maximal cytotoxic concentration: 14900 nM
Compound 4: the middle estimate sits 2.3-fold (0.36 log units) below what was measured, and the stated range covers the measured number.
By their numbers in this assay, from the lowest: compound 1; then compounds 2, 3 and 4 (each within the scatter of the next).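

Going by these compounds alone, the exchange of 2,5-dimethylphenyl for 2-bromo-6-methoxyphenyl gives the first one-place comparison in this assay, with a 3.7-fold higher number from compound 1 to compound 4 (0.56 log units; beyond the scatter) on the aromatic carbon next to the ring nitrogen and next to the ring oxygen. The read-out at this position therefore changes beyond the scatter with the aryl group alone, the rest of compound 1 staying the same. Nothing at hand explains the size or direction of this step.

As far as these compounds go, whether the bromo or the methoxy group alone would give this step stays open, as the two enter together. Also open, from the compounds shown here alone, is how a phenyl ring bearing an amine or a carboxylic acid would read in this assay at this position.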